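Swapping 4-methyl-1H-imidazol-1-yl for sulfamoyl in compound 3

The source may hold more compounds than are shown below. What is called first, only, known or untested is meant among the compounds shown, and "the series" means these compounds.

In a functional assay for inhibition, with Homo sapiens as the target (on this read-out higher numbers stand for weaker inhibition and lower numbers for stronger inhibition), compound 1 `CCc1ccc(Nc2nccc(-c3ccncc3)n2)cc1` gives 7700 nM, and compound 2 `NS(=O)(=O)c1ccc(Nc2nccc(-c3ccccn3)n2)cc1`, which also carries sulfamoyl, gives 4600 nM. Compound 3 `Cc1cn(-c2ccc(Nc3nccc(-c4ccncc4)n3)cc2)cn1` is known only as a limit, > 3000 nM. Compound 4 `NS(=O)(=O)c1ccc(Nc2nccc(-c3ccncc3)n2)cc1` has sulfamoyl in place of 4-methyl-1H-imidazol-1-yl on an aromatic carbon. Among the measured compounds shown here, one measured step touches this position, a step that the limit leaves unreadable from compound 1 to compound 3, so it gives no size to carry over. For the measured compounds named here, with compound 2 at 4600 nM as the only sulfamoyl reading, a large move in either direction is not expected. The expected change is a step that the limit leaves unreadable from compound 3 to compound 4. For compound 4 the estimate is 4000 nM, with an expected range of 1200 nM to 12000 nM.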

Compound 4, half-maximal inhibitory concentration: 5100 nM
Estimate against measurement, compound 4: 1.3-fold (0.11 log units) below; low and high end bracket the measured number.
By their numbers in this assay, from the lowest: compounds 2, 4 and 1 (each within the scatter of the next).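

With pyridin-4-yl in place of pyridin-2-yl, the sulfamoyl compounds show a 1.1-fold higher number from compound 2 to compound 4 (0.04 log units; within the scatter). Sulfamoyl in place of ethyl on this aromatic carbon gives a 1.5-fold lower number from compound 1 to compound 4 (0.18 log units; within the scatter), so neither change at these two places separates the compounds beyond the scatter. Compound 3 stands only as a limit, and the steps to and from it cannot be read: the limit of > 3000 nM in this assay, at which 1 of the 4 values shown sits.

Going by these compounds, whether an amine or a carboxylic acid on this aromatic carbon would move the number beyond the scatter stays open. So does where compound 3 truly stands against compound 4.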